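A few compounds are considered here, and "the series" means these few. Any claim that something is new, unique, unknown or untested is made for them only; others in the source may bear on it.

Working notes on the urea series.

Compound 1 `Cc1cc(NC(=O)Nc2ccc(C(=O)O)cc2)c2ccccc2n1` is assessed in an ADME assay on HepG2 cells (Homo sapiens) for cytotoxicity, with a stated time of 72 h; a lower number here means that less compound is needed, a higher number that more compound is needed for the effect. Compound 1 gives > 25000 nM, which is a limit of the assay and not a number. Compound 2 `Cc1cc(NC(=O)Nc2cc(Cl)cc(Cl)c2)c2ccccc2n1` in this assay gives > 25000 nM, again a limit and not a number. Compound 3 `Cc1cc(NC(=O)Nc2cccc([N+](=O)[O-])c2)c2ccccc2n1` in this assay gives > 25000 nM, also a limit and not a number. Where compound 1 stands on the numbers is thus defined only by the limit of > 25000 nM in this assay, at which 3 of the 3 values shown sit, and every value shown for the shared core sits there; nothing distinguishes compound 1 from compound 2 or compound 3 in this assay.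

Compound 4 `Cc1cc(NC(=O)Nc2ccc(Cl)cc2)c2ccccc2n1` has not been measured. It differs from compound 1 by chloro in place of carboxy on an aromatic carbon. Going by the values given here, no step between two measured compounds is available for this change or for any other change, so the expected size of the step rests on the limits alone.

With all three measured values at the same limit, compound 4 is expected to sit at that limit too, that is, a step from compound 1 of about a step that the limit leaves unreadable from compound 1 to compound 4, which is no movement beyond the scatter. For compound 4 the estimate in this assay is 40000 nM, with a range from 15000 nM to 150000 nM.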

Compound 4, half-maximal effective concentration: > 25000 nM
Compound 4 ended at the assay's limit (the forecaster's own chance of this, stated with the estimate: 85%); the middle value lies beyond the limit too.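

No step can be read from compound 1 to compound 4 in this assay, since the values of both compounds are limits of the assay and not numbers: the limit of > 25000 nM in this assay, at which 4 of the 4 values shown sit.

The compounds shown leave open whether chloro in place of carboxy, or any other change on the shared core, alters the read-out at all.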